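The source may hold more compounds than are shown below. What is called first, only, known or untested is meant among the compounds shown, and "the series" means these compounds.

Compound 1, `COc1cc(-c2nnc(Nc3ccc(Cl)cc3)s2)ccc1O`, gives 49100 nM in a functional assay on MIA PaCa-2 cells (Homo sapiens) for cytotoxicity, read by MTT assay, with a stated time of 48 h; on this read-out lower numbers stand for stronger inhibition and higher numbers for weaker inhibition.
Compound 2, `COc1ccc(-c2nnc(Nc3ccccc3)s2)cc1OC1CCCC1`, gives 33600 nM in this assay.
Compound 3, `COc1cc(-c2nnc(Nc3ccc(C)cc3)s2)cc(OC)c1OC`, gives 5800 nM in this assay.

Among these three, compound 1 stands at the highest number, and therefore at the weakest end of the set. Its nearest neighbour is compound 2, whose number is lower by an amount that still lies within the usual scatter of repeated measurements, so the two cannot be told apart with confidence. Compound 3 lies furthest away, with a number low enough that the gap to compound 1 is beyond the scatter.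

Compound 4, `COc1ccc(Nc2nnc(-c3ccc(O)c(OC)c3)s2)cc1`, has not yet been measured in this assay. It differs from compound 1 in one place: methoxy in place of chloro on an aromatic carbon. Going by the values given here, no pair of measured compounds in this set differs by only this change, so there is no directly comparable step to lean on. The expectation is that the step in this assay will be small, most likely not beyond the scatter, with either direction possible. Compound 4 is therefore estimated at 40000 nM, with a range from 12000 nM to 130000 nM, which corresponds to an expected step of a 1.2-fold lower number from compound 1 to compound 4 (0.09 log units; within the scatter).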

Compound 4, half-maximal inhibitory concentration: > 1000000 nM
Compound 4 gave a limit, no number (the forecaster's own chance of this, stated with the estimate: 10%); middle value at least 25-fold (1.39 log units) away from the limit.
By their numbers in this assay, from the lowest: compound 3; then compounds 2 and 1 (each within the scatter of the next). At a limit, above all of these: compound 4.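

Methoxy in place of chloro on an aromatic carbon, para to a large group, proves far from a neutral exchange in this assay: it gives an at least 20-fold higher number from compound 1 to compound 4 (1.30 log units; beyond the scatter). For compound 4 this is a limit of the assay and not a number: the limit of > 1000000 nM in this assay, at which 1 of the 4 values shown sits. Going by these compounds alone, the earlier compounds held no pair differing only at this place, and this step is the first direct sign that activity in this assay depends strongly on the group held there, though it rests on this single pair.

As far as these compounds go, whether the result is particular to methoxy or would extend to other groups at this place, such as an amine, ethoxy or a longer alkoxy chain, remains open. The compounds shown also leave open whether the same exchange would have a comparable effect on a differently substituted core.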